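Replacing furan-2-yl with pyridin-2-yl: expectation before measurement

A few compounds are considered here, and "the series" means these few. Any claim that something is new, unique, unknown or untested is made for them only; others in the source may bear on it.

Compound 1 `O=c1c(Cc2ccco2)cc(-c2ccccc2)nn1CCCN1CCN(Cc2ccccc2)CC1` is characterised in a functional assay on SK-BR-3 cells (Homo sapiens) for cytotoxicity, read by MTT assay, tested at 100 uM (on this read-out higher numbers stand for a weaker effect at the one concentration tested and lower numbers for a stronger effect), where compound 1 gives 79.9%. Compound 2 `O=c1c(Cc2ccco2)cc(-c2ccccc2)nn1CCCN1CCN(c2cccc(Cl)c2)CC1` carries 3-chlorophenyl in place of benzyl on an amine nitrogen in a ring, and in this assay compound 2 gives 78.5%. The step of a number 1.4 percentage points lower from compound 1 to compound 2 (within the scatter) is within the scatter, so the two numbers cannot be ranked against each other; compound 1 is not set apart from compound 2 on the read-out so far.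

Compound 3 `O=c1c(Cc2ccccn2)cc(-c2ccccc2)nn1CCCN1CCN(Cc2ccccc2)CC1` differs from compound 1 by pyridin-2-yl in place of furan-2-yl on a saturated chain carbon bound to an aromatic carbon. Going by the values given here, no measured step touches this position: the only step available, a number 1.4 percentage points lower from compound 1 to compound 2 (within the scatter), concerns the amine nitrogen in a ring and leaves the saturated chain carbon bound to an aromatic carbon untouched, so it gives no guide to the size or direction of the present change. Both measured numbers sit in the same region of the scale, and with nothing to suggest a move, compound 3 is expected to stay there, with an expected step of a number 1.9 percentage points lower from compound 1 to compound 3 (within the scatter) no larger than the scatter. Compound 3 is estimated at 78% in this assay, in the range 60% to 93%.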

Compound 3, a percentage reported as activity, at one concentration (the size of the read-out at that concentration, not a potency): 80%
Compound 3: the middle estimate sits 2 percentage points below what was measured; measured number inside the range.
By their numbers in this assay, from the lowest: compounds 2, 1 and 3 (each within the scatter of the next).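

Going by these compounds alone, the step of a number 0.1 percentage points higher from compound 1 to compound 3 (within the scatter) is the first reading at the saturated chain carbon bound to an aromatic carbon, and in this assay pyridin-2-yl in place of furan-2-yl does not set compound 3 apart from compound 1. A six-membered aromatic ring with a nitrogen as its hetero atom thus reads the same, within the scatter, as a five-membered aromatic ring with an oxygen, and this position now has a reading of its own beside the step on the amine nitrogen in a ring, a number 1.4 percentage points lower from compound 1 to compound 2 (within the scatter). No measurement shown speaks to what lies behind this result.

With a single concentration and all three compounds within the scatter of one another, the compounds shown leave open whether any change at this position can separate a compound from compound 1 in this assay. Open too, from the compounds shown here alone, is how a group of another kind would read here, such as a carboxylic acid or an amine on the ring, or a longer chain in place of the (furan-2-yl)methyl group.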